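Fluoro on the phenyl of compound 1

This account rests on a few compounds, and the source may have more. Where it says the series, first, only, none or still open, it means among the compounds named here.

In a functional assay on B16-F10 cells (Mus musculus) for antiproliferative activity, read by MTT assay, with a stated time of 48 h (a lower number here means a stronger inhibitor, a higher number a weaker inhibitor), compound 1 (`CC(=O)N1N=C(c2ccc3ccccc3c2)OC1c1ccccc1`) gives 2.57 ug/mL. Compound 2 (`CC(=O)N1N=C(c2ccc3ccccc3c2)OC1c1cccc(Br)c1`) gives 2.36 ug/mL, and compound 3 (`CC(=O)N1N=C(c2ccc3ccccc3c2)OC1c1ccc(Br)cc1`) gives 4.68 ug/mL, so compound 1 stands within the scatter of both. Compound 4 (`CC(=O)N1N=C(c2ccc3ccccc3c2)OC1c1ccccc1F`) has fluoro in place of hydrogen on an aromatic carbon, ortho to a large group: fluoro in place of hydrogen on an aromatic carbon. For the measured compounds named here, no fluoro compound has been measured yet. The closest evidence is the pair of bromo steps, a 1.1-fold lower number from compound 1 to compound 2 (0.04 log units; within the scatter) and a 1.8-fold higher number from compound 1 to compound 3 (0.26 log units; within the scatter), both within the scatter, as is a 2.0-fold higher number from compound 2 to compound 3 (0.30 log units; within the scatter). On that basis, no step beyond the scatter is expected in this assay. The expected step is a 1.1-fold higher number from compound 1 to compound 4 (0.02 log units; within the scatter). Compound 4 is estimated at 2.7 ug/mL, with an expected range of 1.4 ug/mL to 5.2 ug/mL.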

Compound 4, half-maximal inhibitory concentration: 6.05 ug/mL
Beside the measured number, compound 4's estimate is 2.2-fold (0.35 log units) below it; measured number outside the range, above it.
By their numbers in this assay, from the lowest: compounds 2, 1, 3 and 4 (each within the scatter of the next, the first and the last beyond it).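

In this assay, unlike either bromo step, the change to 2-fluorophenyl leaves the scatter, with a 2.4-fold higher number from compound 1 to compound 4 (0.37 log units; beyond the scatter) and a 2.6-fold higher number from compound 2 to compound 4 (0.41 log units; beyond the scatter) as its two modest steps. The gap to the 4-bromophenyl compound does not, at a 1.3-fold higher number from compound 3 to compound 4 (0.11 log units; within the scatter) so a single fluoro ortho to a large group is enough to move the number on this ring. Nothing measured here accounts for the step.
The compounds shown leave open whether the step belongs to fluoro or to its place. A 4-fluorophenyl, or a chloro, methoxy or amine ortho to a large group, would separate the two.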